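The compounds below may be only part of what the source reports. "The series", "measured", "known", "first", "only" and "open" are said of these compounds alone.

Compound 1 `CCC[C@@H]1C[C@@H](c2ccc(Cl)c(Cl)c2)[C@H](NC(=O)c2cc(-c3c(Cl)cnn3C)c(Cl)o2)CN1`: 1020 nM
Compound 2 `Cn1ncc(Cl)c1-c1cc(C(=O)N[C@@H]2CN[C@H](CC(=O)NC3CC3)C[C@H]2c2ccc(Cl)c(Cl)c2)oc1Cl`: 740 nM

For the measured compounds named here, in a functional assay on HCT-116 cells (Homo sapiens) for antiproliferative activity, read by sulforhodamine B assay, with a stated time of 72 h (a higher number here means a weaker inhibitor, a lower number a stronger inhibitor), compound 2 gives 740 nM and stands level with compound 1, the only other compound measured so far. Compound 3 `Cn1ncc(Cl)c1-c1cc(C(=O)N[C@@H]2CN[C@H](CCO)C[C@H]2c2ccc(Cl)c(Cl)c2)oc1Cl` has not been measured. It differs from compound 2 in one place: hydroxymethyl in place of cyclopropylcarbamoyl on a saturated chain carbon bound to a saturated ring carbon. In words, this is hydroxymethyl in place of cyclopropylcarbamoyl on a saturated chain carbon bound to a saturated ring carbon.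

Going by the values given here, only one measured step bears on this place: a 1.4-fold lower number from compound 1 to compound 2 (0.14 log units; within the scatter), with cyclopropylcarbamoyl in place of ethyl. That step lies within the scatter. Among the compounds with values here, no measured compound carries hydroxymethyl here, so the evidence is thin. On that single step, no change beyond the scatter is expected in this assay. The estimate means a 1.2-fold higher number from compound 2 to compound 3 (0.09 log units; within the scatter), which is expected to stay within the scatter. For compound 3 the estimated value is 900 nM, with an expected range of 350 nM to 2300 nM.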

Compound 3, half-maximal inhibitory concentration: 340 nM
Compound 3: the middle estimate sits 2.6-fold (0.42 log units) above what was measured; the whole stated range lies above it.
By their numbers in this assay, from the lowest: compound 3; then compounds 2 and 1 (each within the scatter of the next).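

In this assay, this position proves able to shift the number: hydroxymethyl in place of cyclopropylcarbamoyl gives a 2.2-fold lower number from compound 2 to compound 3 (0.34 log units; beyond the scatter), and hydroxy in place of methyl on a saturated chain carbon, two bonds along the chain from a saturated ring carbon, gives a 3.0-fold lower number from compound 1 to compound 3 (0.48 log units; beyond the scatter). Both steps lie beyond the scatter, so compound 3 is the strongest of the three, although the groups that leave and enter in the first step carry the same counts of hydrogen-bond donors and acceptors. Nothing measured here accounts for these steps.

On these data alone, whether an amine, a carboxylic acid or a longer chain ending in hydroxy would match the 2-hydroxyethyl of compound 3 remains open. Compound 2 and compound 3 also differ in both the carbonyl and the three-membered ring, so the contribution of each cannot be separated.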